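This account rests on a few compounds, and the source may have more. Where it says the series, first, only, none or still open, it means among the compounds named here.

Measured compounds:
- compound 1, `Cc1ccc(N2CCN(c3ccc(C(=O)/C=C/c4ccccc4)cc3)CC2)c(C)c1`: 15%
- compound 2, `Cc1ccc(N2CCN(c3ccc(C(=O)/C=C/c4ccc(Cl)cc4)cc3)CC2)c(C)c1`: 25.7%
- compound 3, `O=C(/C=C/c1ccc(Cl)cc1)c1ccc(N2CCN(S(=O)(=O)c3ccc(C(F)(F)F)cc3)CC2)cc1`: 59.6%

In a functional assay on the whole organism (strain Kunming) for inhibition, with Mus musculus as the target, with a stated time of 1 h, at a dose of 40 mg/kg by the oral route (on this read-out lower numbers stand for less inhibition and higher numbers for more inhibition at the one dose given (going by the name of the read-out)), compound 1 gives 15%, the lowest of the three numbers; compound 2 stands nearest with a number higher by a number 10.7 percentage points higher from compound 1 to compound 2 (beyond the scatter), and compound 3 stands furthest. The unmeasured compound 4, `O=C(/C=C/c1ccccc1)c1ccc(N2CCN(S(=O)(=O)c3ccc(Cl)cc3)CC2)cc1`, differs from compound 1 at one place: (4-chlorophenyl)sulfonyl in place of 2,4-dimethylphenyl on an amine nitrogen in a ring. Within the data shown here, the only measured single-point step, a number 10.7 percentage points higher from compound 1 to compound 2 (beyond the scatter), is a chloro in place of hydrogen on an aromatic carbon of the chalcone ring and so does not touch the amine nitrogen in the ring where compound 4 changes. What the other values show is that compound 3, which carries a sulfonyl group on that ring nitrogen alongside a chloro on the chalcone ring, gives 59.6%, well above compound 2 at 25.7%. On that basis compound 4 is expected to rise from compound 1 by roughly a number 30 percentage points higher from compound 1 to compound 4 (beyond the scatter), beyond the scatter, toward an estimated 45% in this assay, within a range of 25% to 65%.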

Compound 4, a percentage reported as inhibition, in the whole organism at one dose (the size of the read-out at that dose, not a potency): 46.8%
The estimate for compound 4 lay 1.8 percentage points below the measured number; measured number inside the range.
By their numbers in this assay, from the lowest: compound 1; then compound 2; then compound 4; then compound 3.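

In this assay, the amine nitrogen in a ring proves a position where a single change moves the read-out far: (4-chlorophenyl)sulfonyl in place of 2,4-dimethylphenyl gives a number 31.8 percentage points higher from compound 1 to compound 4 (beyond the scatter), with the rest of the core of compound 1 unchanged. Among these compounds, the earlier compounds gave no such reading, as the one earlier step lay on an aromatic carbon and compound 3 differs from compound 1 in more than one place. Nothing available accounts for the size of this step.

The change brings in the sulfonyl and the chlorine together, so the compounds shown do not separate their shares in the step. From the compounds shown here alone, how a methylsulfonyl or a benzoyl group on the same nitrogen would read in this assay remains open.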